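The source may hold more compounds than are shown below. What is called first, only, known or untested is meant among the compounds shown, and "the series" means these compounds.

The measured compounds, all in an assay on cells for inhibition of S-adenosylmethionine decarboxylase proenzyme (Homo sapiens), read by mass spectrometry, at pH 7.2; on this read-out lower numbers stand for stronger inhibition and higher numbers for weaker inhibition:

Compound 1 `Cc1cc(Nc2cccc(Cl)c2)nc(N)n1` gives > 180000 nM, which is a limit of the assay rather than a number.
Compound 2 `Cc1cc(Nc2cccc(F)c2)nc(N)n1` gives > 180000 nM, also a limit.
Compound 3 `Cc1cc(Nc2cc(Cl)ccc2C)nc(N)n1` gives > 180000 nM, again a limit.

So compound 1 stands at the edge of what this assay can report, and nothing separates it from its two neighbours. The step that the two limits leave unreadable from compound 1 to compound 2 and the step that the two limits leave unreadable from compound 1 to compound 3 both fall between two limits, so neither their size nor their direction can be read. This follows from the limit of > 180000 nM in this assay, at which 3 of the 3 values shown sit.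

Compound 4 `Cc1cc(Nc2cc(Cl)cc(-c3ccc(C#N)cc3)c2)nc(N)n1` arises from compound 1 by a larger change: 4-cyanophenyl in place of hydrogen on an aromatic carbon. Within the data shown here, no measured step resembles it, and the two steps that exist give no readable size at all. Among the measured compounds shown here, the expected step of an at least 1.2-fold lower number from compound 1 to compound 4 (0.07 log units; that floor lies within the scatter) therefore rests on no measured precedent and is set close to where compound 1 stands, because compound 1 gives only the limit > 180000 nM. Compound 4 is estimated at 150000 nM, with a range from 20000 nM to 400000 nM, and most likely this assay again reports only a limit for compound 4.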

Compound 4, half-maximal inhibitory concentration: > 7000 nM
Compound 4 gave a limit, no number (the forecaster's own chance of this, stated with the estimate: 65%); the middle value is on the limit's open side.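

In this assay, compound 1 and compound 4 each give only a limit, not a number, so the step between them cannot be read in size or direction. The compounds shown leave open whether 4-cyanophenyl in place of hydrogen changes inhibition at all.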